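Sulfonyl substituent variation in an indole enone series

A few compounds are considered here, and "the series" means these few. Any claim that something is new, unique, unknown or untested is made for them only; others in the source may bear on it.

Measured compounds:
compound 1 `CC(C)(C)c1ccc(S(=O)(=O)n2cc(/C=C/C(=O)c3ccncc3)c3ccccc32)cc1` — 27000 nM
compound 2 `CCCS(=O)(=O)n1cc(/C=C/C(=O)c2ccncc2)c2ccccc21` — 46200 nM
compound 3 `O=C(/C=C/c1cn(S(=O)(=O)c2cccc3ccccc23)c2ccccc12)c1ccncc1` — 62900 nM

In a functional assay on HepG2 cells (Homo sapiens) for antiproliferative activity, read by MTT assay, with a stated time of 48 h (on this read-out higher numbers stand for weaker inhibition and lower numbers for stronger inhibition), compound 2 stands second highest of the three numbers; compound 3 lies nearest, and compound 1 furthest, both within the scatter of compound 2. Compound 4 `O=C(/C=C/c1cn(S(=O)(=O)c2ccc([N+](=O)[O-])cc2)c2ccccc12)c1ccncc1` is the next member to be measured. It differs from compound 2 in one place: 4-nitrophenyl in place of propyl on a sulfonyl sulfur.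

Among the measured compounds shown here, two measured steps bear on this change, since each swaps the propyl on the sulfonyl sulfur for an aromatic group. The step of a 1.7-fold higher number from compound 1 to compound 2 (0.23 log units; within the scatter) and the step of a 1.4-fold higher number from compound 2 to compound 3 (0.13 log units; within the scatter) both stay within the scatter, and they point in opposite directions. For the measured compounds named here, the only step beyond the scatter, a 2.3-fold higher number from compound 1 to compound 3 (0.37 log units; beyond the scatter), compares two aromatic groups with each other and is modest. Nothing here suggests that an aromatic group on the sulfonyl sulfur moves this read-out beyond the scatter in either direction, so no step beyond the scatter is expected for compound 4.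

Compound 4 is therefore expected to give about 40000 nM in this assay, with a range from 18000 nM to 90000 nM. The expected step is a 1.2-fold lower number from compound 2 to compound 4 (0.06 log units; within the scatter).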

Compound 4, half-maximal inhibitory concentration: 18300 nM
Estimate against measurement, compound 4: 2.2-fold (0.34 log units) above; low and high end bracket the measured number.
By their numbers in this assay, from the lowest: compounds 4, 1, 2 and 3 (each within the scatter of the next, the first and the last beyond it).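

The sulfonyl sulfur now shows a step beyond the scatter on leaving propyl: 4-nitrophenyl gives a 2.5-fold lower number from compound 2 to compound 4 (0.40 log units; beyond the scatter), while 4-(tert-butyl)phenyl and naphthalen-1-yl stayed within the scatter of propyl. The choice of aromatic group also matters here, with 4-nitrophenyl in place of naphthalen-1-yl giving a 3.4-fold lower number from compound 3 to compound 4 (0.54 log units; beyond the scatter), although nitro in place of tert-butyl on an aromatic carbon gives only a 1.5-fold lower number from compound 1 to compound 4 (0.17 log units; within the scatter) and so does not separate these two substituted phenyl groups. No measurement is available that bears on the cause of these steps.

The compounds shown leave open whether the step from propyl belongs to the nitro group or to the phenyl ring, which an unsubstituted phenyl or a phenyl carrying an amine or a carboxylic acid on the sulfonyl sulfur could help separate. They also leave open how a longer chain in place of propyl would compare with compound 2.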